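Replacing the thioether arm of compound 1 with a methylpiperazine

The compounds below may be only part of what the source reports. "The series", "measured", "known", "first", "only" and "open" are said of these compounds alone.

Measured compounds:
- compound 1, `Cn1c(-c2ccc(NC(=O)CSc3nc4ccccc4s3)cc2)nc(-c2ccccc2)c1-c1ccccc1`: 82.7%
- compound 2, `Cn1c(-c2ccc(NC(=O)CSC3=NCCS3)cc2)nc(-c2ccccc2)c1-c1ccccc1`: 75.2%

In a functional assay on HT-29 cells (Homo sapiens) for cytotoxicity, read by MTT assay, with a stated time of 24 h, tested at 80 ug/mL (on this read-out lower numbers stand for a weaker effect and higher numbers for a stronger effect at the one concentration tested), compound 1 gives 82.7% and stands highest of the two measured numbers, though compound 2 with 75.2% lies within the scatter of it. Among the compounds with values here, the one measured step, a number 7.5 percentage points lower from compound 1 to compound 2 (within the scatter), exchanges the heterocycle on the sulfur while the sulfur itself is kept.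

Compound 3, `CN1CCN(CC(=O)Nc2ccc(-c3nc(-c4ccccc4)c(-c4ccccc4)n3C)cc2)CC1`, has not been measured. It differs from compound 1 by 4-methylpiperazin-1-yl in place of (1,3-benzothiazol-2-yl)sulfanyl on a saturated chain carbon bound to a carbonyl carbon. Here the sulfur leaves together with its aromatic rings, so the step from compound 1 to compound 2 bears on it only loosely: that step, which also removed the aromatic rings from the group on the sulfur, stayed within the scatter. Within the data shown here, no measured step covers a change in which a non-aromatic nitrogen ring is joined directly to the chain carbon.

On this basis compound 3 is expected to remain close to compound 1, with a step of a number 10.7 percentage points lower from compound 1 to compound 3 (beyond the scatter) that need not exceed the scatter. The estimate for compound 3 is 72%, within 52% to 88%.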

Compound 3, a percentage reported as activity, at one concentration (the size of the read-out at that concentration, not a potency): 53.1%
Compound 3: middle estimate off by 18.9 percentage points, on the high side, and the stated range covers the measured number.
By their numbers in this assay, from the lowest: compound 3; then compounds 2 and 1 (each within the scatter of the next).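

In this assay the saturated chain carbon bound to a carbonyl carbon proves sensitive to what it carries: placing 4-methylpiperazin-1-yl there gives a number 29.6 percentage points lower from compound 1 to compound 3 (beyond the scatter) and a number 22.1 percentage points lower from compound 2 to compound 3 (beyond the scatter) against the two sulfur-linked compounds. Compound 3 therefore stands lowest of the three, with both of its steps beyond the scatter. Within the data shown here, this is the first change at this position that moves the number that far, since the exchange of the heterocycle on the sulfur had stayed within the scatter even though it removed the aromatic rings, whereas here the sulfur leaves as well and a non-aromatic nitrogen ring is joined directly to the chain carbon.

The compounds shown cannot separate the loss of the sulfur from the entry of the piperazine ring, and they leave open how a morpholine ring or an open-chain dimethylamino group on the same chain carbon would read. No evidence is available that accounts for the lower number of compound 3.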